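This account rests on a few compounds, and the source may have more. Where it says the series, first, only, none or still open, it means among the compounds named here.

Working notes on the fibroblast growth factor 2 disaccharide series.

Four compounds share one core: compound 1 `CC(=O)N[C@H]1[C@@H](OC[C@@H](O)[C@@H](O)[C@H](O)[C@@H](O)CNc2cccc(NC(=O)CCCCC3CCSS3)c2)O[C@H](CO)[C@H](O)[C@@H]1O[C@@H]1O[C@H](C(=O)O)[C@@H](O)[C@H](O)[C@H]1O`, compound 2 `CC(=O)N[C@H]1[C@@H](OC[C@@H](O)[C@@H](O)[C@H](O)[C@@H](O)CNc2cccc(NC(=O)CCCCC3CCSS3)c2)O[C@H](CO)[C@H](OS(=O)(=O)O)[C@@H]1O[C@@H]1O[C@H](C(=O)O)[C@@H](O)[C@H](O)[C@H]1O`, compound 3 `CC(=O)N[C@H]1[C@@H](OC[C@@H](O)[C@@H](O)[C@H](O)[C@@H](O)CNc2cccc(NC(=O)CCCCC3CCSS3)c2)O[C@H](CO)[C@H](O)[C@@H]1O[C@@H]1O[C@H](C(=O)O)[C@@H](O)[C@H](O)[C@H]1OS(=O)(=O)O` and compound 4 `CC(=O)N[C@H]1[C@@H](OC[C@@H](O)[C@@H](O)[C@H](O)[C@@H](O)CNc2cccc(NC(=O)CCCCC3CCSS3)c2)O[C@H](CO)[C@H](OS(=O)(=O)O)[C@@H]1O[C@@H]1O[C@H](C(=O)O)[C@@H](O)[C@H](O)[C@H]1OS(=O)(=O)O`. In an assay on isolated protein for binding affinity to fibroblast growth factor 2 (Homo sapiens), read by surface plasmon resonance (a lower number here means tighter binding, a higher number weaker binding), compound 1 gives "not active" (no number reported). In this assay compound 2 gives "not active" (no number reported). In this assay, among the compounds with values here, compound 3 gives 62 nM, the only numerical value so far; compound 1 and compound 2 return no number at all, so compound 3 stands alone as the one member with measurable affinity.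

The step from compound 3 to compound 4 is sulfo in place of hydrogen on an oxygen on a saturated carbon. This change turns a hydroxy into a sulfooxy, so compound 4 carries two sulfo groups where compound 3 carries one. Within the data shown here, no measured pair differs in a single place, so no directly comparable step is known. Given that compound 3 with one sulfo group gives 62 nM while compound 1 without any gives "not active" (no number reported), a second sulfo group is expected to leave affinity unchanged or to tighten it by a modest step, estimated as a 2.1-fold lower number from compound 3 to compound 4 (0.32 log units; beyond the scatter). For compound 4 in this assay the expected value is 30 nM, with a range of 8 nM to 150 nM.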

Compound 4, dissociation constant: 41 nM
Beside the measured number, compound 4's estimate is 1.4-fold (0.14 log units) below it; the measured number falls inside the stated range.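

Working notes, step from compound 3 to compound 4: in this assay the change from hydroxy to sulfooxy at this position reads as a 1.5-fold lower number from compound 3 to compound 4 (0.18 log units; within the scatter) and so gives no readable gain in affinity once the sulfooxy of compound 3 is present. Compound 2 carries the sulfooxy of this position without the one in compound 3, and in this assay compound 2 gives "not active" (no number reported), whereas, one place away from compound 2, compound 4 gives 41 nM in the same assay, so among these compounds a number appears only where the sulfooxy of compound 3 is present. No measurement on hand bears on why this position adds so little.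

The compounds shown leave open whether this position tolerates other groups as well as it tolerates hydroxy and sulfooxy, for instance a phosphate ester, an amine or a methyl ether in their place. Within the data shown here, they also leave open whether a sulfooxy at any other hydroxy of the shared core would behave like the one at this position or like the one in compound 3.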